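Swapping a thiazole for a methylthiophene on the pyrimidine core

The source may report more compounds than this note shows. Statements on the series, on what has been measured and on what is new or still open speak of the compounds shown alone.

Measured compounds:
- In a functional assay on Jurkat cells (Homo sapiens) for inhibition (on this read-out higher numbers stand for weaker inhibition and lower numbers for stronger inhibition), compound 1 `CCOC(=O)c1cnc(NN2C(=O)C=C(C)C2=O)nc1-c1nccs1` gives 2200 nM.
- In this assay compound 2 `CCOC(=O)c1cnc(N(C)N2C(=O)C=C(C)C2=O)nc1CC` gives 35 nM.
- In this assay compound 3 `CCOC(=O)c1cnc(N(C)N2C(=O)C=C(C)C2=O)nc1-c1nccs1` gives 1700 nM.

Compound 3 stands second highest of the three numbers. Its step from compound 1, a 1.3-fold lower number from compound 1 to compound 3 (0.11 log units; within the scatter), lies within the scatter, so the two cannot be ordered. The step of a 49-fold higher number from compound 2 to compound 3 (1.69 log units; beyond the scatter) is large and beyond the scatter.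

Compound 4 `CCOC(=O)c1cnc(N(C)N2C(=O)C=C(C)C2=O)nc1-c1ccc(C)s1` differs from compound 3 in one place: 5-methylthiophen-2-yl in place of 1,3-thiazol-2-yl on an aromatic carbon. Among the compounds with values here, no measured step replaces one five-membered aromatic ring by another at this carbon. Within the data shown here, the only step at this position, a 49-fold higher number from compound 2 to compound 3 (1.69 log units; beyond the scatter), shows that replacing ethyl with a five-membered aromatic ring raised the number sharply; compound 4 keeps such a ring, so the expected step of a 1.4-fold lower number from compound 3 to compound 4 (0.15 log units; within the scatter) in this assay is small and uncertain in direction. Compound 4 is therefore estimated at 1200 nM, with a range from 300 nM to 5000 nM.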

Compound 4, half-maximal inhibitory concentration: 350 nM
Beside the measured number, compound 4's estimate is 3.4-fold (0.54 log units) above it; low and high end bracket the measured number.
By their numbers in this assay, from the lowest: compound 2; then compound 4; then compounds 3 and 1 (each within the scatter of the next).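

Within the data shown here, this is the first comparison of one five-membered aromatic ring with another at this carbon, and in this assay the choice of ring matters (a 4.9-fold lower number from compound 3 to compound 4 (0.69 log units; beyond the scatter)). A five-membered aromatic ring here therefore need not cost as much as the 1,3-thiazol-2-yl group did, although 5-methylthiophen-2-yl still falls short of ethyl (a 10-fold higher number from compound 2 to compound 4 (1.00 log units; beyond the scatter)). No measurement at hand explains the difference between the two rings.

Compound 4 changes the ring atoms and adds a methyl group in a single step, so the data cannot say which of the two accounts for the lower number, and a plain thiophen-2-yl group would help to separate them. Also open, going by these compounds, is how a propyl chain or a phenyl ring on this carbon would compare with ethyl and with the two five-membered rings.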